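Urea to amide on the anilide arm of compound 3

This account rests on a few compounds, and the source may have more. Where it says the series, first, only, none or still open, it means among the compounds named here.

Going by the values given here, in a functional assay on OVCAR-4 cells (Homo sapiens) for inhibition, read by sulforhodamine B assay, with a stated time of 48 h (on this read-out higher numbers stand for weaker inhibition of growth and lower numbers for stronger inhibition of growth), compound 3 `COc1cc(-c2nn(-c3cccc(NC(=O)Nc4cccc(C(F)(F)F)c4)c3)cc2-c2ccncc2)ccc1Cl` gives 2100 nM, the only number among the three measured values. Compound 1 `COc1cc(-c2nn(-c3cccc(NC(=O)c4cccc(C(F)(F)F)c4)c3)cc2-c2ccncc2)ccc1Cl` reports only a limit, > 50000 nM. Compound 2 `COc1cc(-c2nn(-c3cccc(NC(=O)Nc4ccc(Cl)c(Cl)c4)c3)cc2-c2ccncc2)ccc1Cl` likewise reports only a limit, > 50000 nM. Compound 4 `COc1cc(-c2nn(-c3cccc(NC(=O)c4ccc(Cl)c(C(F)(F)F)c4)c3)cc2-c2ccncc2)ccc1Cl` differs from compound 3 by 4-chloro-3-(trifluoromethyl)phenyl in place of (3-(trifluoromethyl)phenyl)amino on a carbonyl carbon, which turns the urea into an amide. The closest measured step runs the opposite way: an at least 23-fold lower number from compound 1 to compound 3 (1.37 log units; beyond the scatter). The step of an at least 23-fold lower number from compound 2 to compound 3 (1.37 log units; beyond the scatter) also arrives at compound 3 from a limit. Reversing that first step in compound 4 is therefore expected to give a large rise, a 33-fold higher number from compound 3 to compound 4 (1.52 log units; beyond the scatter), and the value is expected to land at the limit of > 50000 nM in this assay, at which 2 of the 3 values shown sit. For compound 4 the estimate is 70000 nM, within 20000 nM to 250000 nM.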

Compound 4, concentration for total growth inhibition: > 32500 nM
Compound 4 ended at the assay's limit (the forecaster's own chance of this, stated with the estimate: 75%); the middle value lies beyond the limit too.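

In this assay, the amide with 4-chloro-3-(trifluoromethyl)phenyl on the carbonyl carbon does not recover the activity of the urea, giving an at least 15-fold higher number from compound 3 to compound 4 (1.18 log units; beyond the scatter). Adding chloro to the amide arm of compound 1 therefore still leaves no readable number. Compound 4 gives only a limit: the limit of > 32500 nM in this assay, at which 1 of the 4 values shown sits.

From the compounds shown here alone, the steps to compound 4 from compound 1 and compound 2 cannot be read, so any effect of that chloro on the amide stays open. Also open, going by these compounds, is whether a urea carrying a methoxy or nitrile in place of trifluoromethyl would give a readable number.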